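The source may hold more compounds than are shown below. What is called first, only, known or untested is meant among the compounds shown, and "the series" means these compounds.

Working notes on the series.

Two compounds sharing one core have been run in an ADME assay on MDBK cells (Bos taurus) for cytotoxicity; on this read-out higher numbers stand for lower toxicity in this test and lower numbers for higher toxicity in this test. Compound 1 `Fc1cccc(F)c1-c1nc2ccn(Cc3ccccc3)cc-2n1` carries a benzyl group on the core nitrogen. In this assay compound 1 gives > 100000 nM, which is a limit of the assay and not a number. Compound 2 `COc1cccc(Cn2ccc3nc(-c4ccccc4)nc-3c2)c1` carries 3-methoxyphenyl on the same chain carbon. In this assay compound 2 gives > 100000 nM, again a limit and not a number. Within the data shown here, compound 2 therefore stands at the limit of > 100000 nM in this assay, at which 2 of the 2 values shown sit; no step between measured compounds can be sized, and nothing here separates compound 1 from compound 2.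

The next compound, compound 3 `N#Cc1ccc(Cn2ccc3nc(-c4ccccc4)nc-3c2)cc1`, differs from compound 2 in one place: 4-cyanophenyl in place of 3-methoxyphenyl on a saturated chain carbon bound to an aromatic nitrogen. With both measured compounds at the same limit, no direction can be read from the series; the expected step of a number no higher from compound 2 to compound 3 (the limit leaves the size open) is none beyond the usual scatter. Compound 3 is expected to give 100000 nM in this assay, with a range from 40000 nM to 300000 nM, most likely reported again as a limit, which a measurement will settle.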

Compound 3, half-maximal cytotoxic concentration: > 100000 nM
Compound 3 gave a limit, no number; the forecaster's own chance of this, stated with the estimate: 80%; the middle value lies on the limit itself.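

In this assay compound 3 gives > 100000 nM, again a limit of the assay and not a number. No step can be read from compound 2 to compound 3, and the series stands thus: the limit of > 100000 nM in this assay, at which 3 of the 3 values shown sit. The compounds shown leave open how far each lies from that limit and whether any change on the shared core would give a measurable value.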